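Quinoline thiosemicarbazones: aryl para substituent in antiproliferative assay

A few compounds are considered here, and "the series" means these few. Any claim that something is new, unique, unknown or untested is made for them only; others in the source may bear on it.

Measured so far:
compound 1, `COc1ccc(C)cc1NC(=S)N/N=C/c1ccc2ccccc2n1`: > 100000 nM
compound 2, `N#Cc1ccc(NC(=S)N/N=C/c2ccc3ccccc3n2)cc1`: 23700 nM

In a functional assay on SGC-7901 cells (Homo sapiens) for antiproliferative activity, read by sulforhodamine B assay, with a stated time of 72 h (on this read-out lower numbers stand for stronger inhibition and higher numbers for weaker inhibition), compound 1 gives only a limit, > 100000 nM. Among the measured compounds shown here, compound 2 gives 23700 nM in this assay, the single numeric value, the other result being (the limit of > 100000 nM in this assay, at which 1 of the 2 values shown sits). Compound 3, `S=C(N/N=C/c1ccc2ccccc2n1)Nc1ccc(Br)cc1`, differs from compound 2 by bromo in place of cyano on an aromatic carbon. For the measured compounds named here, no measured step of this kind exists, so the expected change from compound 2 to compound 3 is none beyond the scatter, a 1.1-fold higher number from compound 2 to compound 3 (0.02 log units; within the scatter). Compound 3 is estimated at 25000 nM in this assay, between 6000 nM and 100000 nM.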

Compound 3, half-maximal inhibitory concentration: 69400 nM
Compound 3: the middle estimate sits 2.8-fold (0.44 log units) below what was measured; the measured number falls inside the stated range.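

The aryl substituent para to a large group is not a silent position: in this assay, exchanging cyano for bromo gives a 2.9-fold higher number from compound 2 to compound 3 (0.47 log units; beyond the scatter). Among the compounds shown here, this is the first step that can be read as a size, and it favours the 4-cyanophenyl compound. Compound 1 stays a limit and gives no step: the limit of > 100000 nM in this assay, at which 1 of the 3 values shown sits.

A single exchange leaves open whether cyano is specially favoured here or bromo is merely less well tolerated. As far as these compounds go, how an amine or a carboxylic acid would read at this place remains open.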